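This account rests on a few compounds, and the source may have more. Where it says the series, first, only, none or still open, it means among the compounds named here.

Measured in a functional assay on BAEC cells (Bos taurus) for antiproliferative activity, read by cell counting, with a stated time of 4 days; on this read-out lower numbers stand for stronger inhibition and higher numbers for weaker inhibition:

- Compound 1 `CCOC(=O)CN(Cc1ccc(F)cc1)c1ccc2c(c1)OC(C)(COc1ccc(C#N)cc1)CN2C`: 50000 nM
- Compound 2 `CCOC(=O)CN(Cc1cc(F)cc(F)c1)c1ccc2c(c1)N(C)CC(C)(COc1ccc(C#N)cc1)O2`: > 100000 nM (a limit of the assay)

Only compound 1 has a numerical value in this assay. On these data alone, compound 2 gives > 100000 nM, which is a limit and not a number, so its true position on the scale is unknown.

Compound 3 `CCOC(=O)CN(Cc1cc(F)cc(F)c1)c1ccc2c(c1)N(C)CC(C)(COc1ccc(C(=N)N)cc1)O2` keeps everything in compound 2 except the cyano group, which is replaced on an aromatic carbon, para to a large group: a group of 3 heavy atoms (1 carbon, 2 nitrogen; no ring) in place of a group of 2 heavy atoms (1 carbon, 1 nitrogen; no ring), on an aromatic carbon.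

Within the data shown here, no measured pair of compounds shows what this replacement does, so the expectation is loose. A moderate move towards stronger inhibition is expected, with the estimated step being an at least 5.0-fold lower number from compound 2 to compound 3 (0.69 log units; beyond the scatter). A result that again reaches the limit would not be surprising. The estimated value for compound 3 is 20000 nM, with an expected range of 2000 nM to 100000 nM.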

Compound 3, half-maximal inhibitory concentration: 4000 nM
Beside the measured number, compound 3's estimate is 5.0-fold (0.70 log units) above it; low and high end bracket the measured number.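

In this assay, the aromatic carbon para to a large group proves sensitive to what it carries: the group of 3 heavy atoms in place of the cyano group gives an at least 25-fold lower number from compound 2 to compound 3 (1.39 log units; beyond the scatter), and the result is a numerical value where there was none. Compound 2 gives > 100000 nM, which is a limit and not a number. The step therefore has only a lower bound and its full size stays unknown, because it starts from a limit: the limit of > 100000 nM in this assay, at which 1 of the 3 values shown sits.

On these data alone, it remains open whether this change is specific to the group that entered, or whether an aminomethyl group or a carboxylic acid at the same place would give a similar result. As far as these compounds go, it is also open whether the same replacement would have a comparable effect on the structure of compound 1.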